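Carbamate to Aryl Amide on the Piperidine Valine Scaffold

This account rests on a few compounds, and the source may have more. Where it says the series, first, only, none or still open, it means among the compounds named here.

Three measured compounds share a core in which a valine-derived amide carries a 4-(4-chlorophenyl)piperidine. Compound 1 `Cc1ccc(C(=O)N[C@@H](C(=O)N2CCC(c3ccc(Cl)cc3)CC2)C(C)C)cc1` gives 25 nM in an assay on THP-1 cells for displacement of a labelled ligand from C-C chemokine receptor type 1 (Homo sapiens); a lower number here means a stronger inhibitor, a higher number a weaker inhibitor. For the measured compounds named here, compound 3 `CC(C)[C@@H](NC(=O)c1nc2ccccc2s1)C(=O)N1CCC(c2ccc(Cl)cc2)CC1` gives 18 nM in this assay, and the only single-point step among them, a 1.4-fold lower number from compound 1 to compound 3 (0.14 log units; within the scatter), is small. Compound 2 `CC(C)C(NC(=O)Oc1ccccc1)C(=O)N1CCC(c2ccc(Cl)cc2)CC1` stands apart: in this assay compound 2 gives 265 nM, the highest of the three numbers, with compound 1 below it and compound 3 further still, both gaps beyond the scatter.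

Compound 4 `Cc1ccccc1C(=O)NC(C(=O)N1CCC(c2ccc(Cl)cc2)CC1)C(C)C` is not yet measured. Relative to compound 2 the change is 2-methylphenyl in place of phenoxy on a carbonyl carbon. No measured step covers exactly this exchange, so the listed step from compound 1 to compound 3 does not bear on it directly. What the numbers do show is that the two aryl amides, compound 1 and compound 3, sit well below the carbamate compound 2 in this assay. On that basis compound 4, an aryl amide with a 2-methylphenyl group, is expected to move toward those two, an expected step of a 5.3-fold lower number from compound 2 to compound 4 (0.72 log units; beyond the scatter). Compound 4 is estimated at 50 nM in this assay, within a range of 15 nM to 200 nM.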

Compound 4, half-maximal inhibitory concentration: 36 nM
Beside the measured number, compound 4's estimate is 1.4-fold (0.14 log units) above it, within the range that was stated.
By their numbers in this assay, from the lowest: compounds 3, 1 and 4 (each within the scatter of the next); then compound 2.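

In this assay, the exchange on a carbonyl carbon whose other neighbour is an amide-type nitrogen gives a 7.4-fold lower number from compound 2 to compound 4 (0.87 log units; beyond the scatter), the first direct single-place measure of what leaving the phenoxy group costs or gains here. The earlier compounds shown here showed only that two aryl amides lay well below the carbamate, whereas this step holds the count of 7 heavy atoms and the one six-membered aromatic ring of carbon only constant, while the oxygen of phenoxy gives way to the carbons of 2-methylphenyl, and compound 4 now falls within the scatter of compound 1. Nothing shown here accounts for the size of this step.

The compounds shown do not separate the linking oxygen from the methyl group, since the step changes both at once, and a plain phenyl group on the same carbonyl carbon would be needed to tell them apart. They also leave open how a phenylamino group, which would turn the carbamate into a urea, or a smaller methoxy group would read at this position.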